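Chlorine placement on the benzyl group near the limit

A few compounds are considered here, and "the series" means these few. Any claim that something is new, unique, unknown or untested is made for them only; others in the source may bear on it.

In a functional assay on HeLa cells (Homo sapiens) for antiproliferative activity, with a stated time of 24 h (a lower number here means a stronger inhibitor, a higher number a weaker inhibitor), compound 1 (`NC(=O)c1c(NC(=O)c2ccccc2Cl)sc2c1CCNC2`) gives 45000 nM. Compound 2 (`NC(=O)c1c(NC(=O)c2ccccc2Cl)sc2c1CCN(Cc1ccccc1)C2`), with benzyl in place of hydrogen on the amine nitrogen in a ring, gives 38400 nM. Compound 3 (`NC(=O)c1c(NC(=O)c2ccccc2Cl)sc2c1CCN(Cc1ccc(Cl)cc1)C2`), with 4-chlorobenzyl at that nitrogen, gives no number, only a limit of > 50000 nM. Compound 3 thus stands at the limit of > 50000 nM in this assay, at which 1 of the 3 values shown sits.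

Compound 4 (`NC(=O)c1c(NC(=O)c2ccccc2Cl)sc2c1CCN(Cc1c(Cl)cccc1Cl)C2`) keeps the shared core and carries 2,6-dichlorophenyl in place of 4-chlorophenyl on a saturated chain carbon bound to an amine nitrogen in a ring. The same difference reads as 4-chlorobenzyl to 2,6-dichlorobenzyl.

Within the data shown here, three measured steps bear on this change. Benzyl in place of hydrogen gave a 1.2-fold lower number from compound 1 to compound 2 (0.07 log units; within the scatter). 4-Chlorobenzyl in place of hydrogen gave an at least 1.1-fold higher number from compound 1 to compound 3 (0.04 log units; that floor lies within the scatter). Chloro in place of hydrogen on an aromatic carbon gave an at least 1.3-fold higher number from compound 2 to compound 3 (0.11 log units; that floor lies within the scatter). None of these shows a change beyond the scatter, although the two steps ending at compound 3 rest on a limit. No step beyond the scatter is therefore expected in this assay, and no firm direction can be assigned. The expected change is an at least 1.1-fold lower number from compound 3 to compound 4 (0.04 log units; that floor lies within the scatter). A report as a limit is also a real possibility. The estimated value for compound 4 is 45000 nM, with an expected range of 22000 nM to 80000 nM.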

Compound 4, half-maximal inhibitory concentration: 28800 nM
Compound 4: the middle estimate sits 1.6-fold (0.19 log units) above what was measured; the measured number falls inside the stated range.
By their numbers in this assay, from the lowest: compounds 4, 2 and 1 (each within the scatter of the next). At a limit, above all of these: compound 3.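

In this assay, 2,6-dichlorophenyl on a saturated chain carbon bound to an amine nitrogen in a ring yields a measured number where 4-chlorophenyl at that place did not, and the comparison can be stated only as an at least 1.7-fold lower number from compound 3 to compound 4 (0.23 log units; that floor lies within the scatter). Compound 3 is reported only as a limit: the limit of > 50000 nM in this assay, at which 1 of the 4 values shown sits. Set against the two measured neighbours, the new group gives a 1.3-fold lower number from compound 2 to compound 4 (0.12 log units; within the scatter) and a 1.6-fold lower number from compound 1 to compound 4 (0.19 log units; within the scatter), so the measured compounds at this nitrogen, with hydrogen, benzyl or 2,6-dichlorobenzyl, show no separation beyond the scatter.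

Going by these compounds, it remains open whether any substituent at this nitrogen can move the number in this assay beyond the scatter, since all three measured compounds sit close together and compound 3 offers no number to compare. A longer chain such as phenethyl, or a benzyl group carrying a methoxy group, an amine or a carboxylic acid, would test whether this position responds to anything other than the chlorine pattern on the phenyl ring.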